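Working notes: a new aryl group on the shared core

The source may report more compounds than this note shows. Statements on the series, on what has been measured and on what is new or still open speak of the compounds shown alone.

Measured so far:
compound 1 `CC(=O)Oc1cccc(N2C(=O)/C(=C/N3N=C(c4ccccc4)CC3c3ccccc3O)SC2=S)c1` gives 118 nM.
compound 2 `CCN1C(=O)/C(=C/N2N=C(c3ccccc3)CC2c2ccccc2O)SC1=S` sits at the limit > 10000 nM, which is a limit of the assay and not a number.
compound 3 `O=C1/C(=C/N2N=C(c3ccccc3)CC2c2ccccc2O)SC(=S)N1c1cccnc1` gives 720 nM.

The read-out throughout is a functional assay on HL-60 cells (Homo sapiens) for antiproliferative activity, read by MTT assay, with a stated time of 72 h; a higher number here means a weaker inhibitor, a lower number a stronger inhibitor. Compound 1 holds the lowest of the two numbers shown; its nearest neighbour is compound 3, separated by a 6.1-fold higher number from compound 1 to compound 3 (0.79 log units; beyond the scatter). The other measured steps, an at least 84-fold higher number from compound 1 to compound 2 (1.92 log units; beyond the scatter) and an at least 13-fold lower number from compound 2 to compound 3 (1.14 log units; beyond the scatter), are large, and one of them rests on (the limit of > 10000 nM in this assay, at which 1 of the 3 values shown sits). All three steps change only the group on the amide-type nitrogen in the ring.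

Compound 4 `CC(=O)Oc1cccc(N2C(=O)/C(=C/N3N=C(c4ccccc4)CC3c3ccc(N(C)C)cc3)SC2=S)c1` is the next case. It keeps the 3-acetoxyphenyl on the amide-type nitrogen of compound 1 and differs elsewhere: 4-(dimethylamino)phenyl in place of 2-hydroxyphenyl on a saturated ring carbon. For the measured compounds named here, no measured step touches this saturated ring carbon, so none of the steps above bears on the change directly; they only show that the nitrogen substituent, which compound 4 leaves as in compound 1, can move the number a lot. Without a step at this position, no direction beyond the scatter is expected for compound 4 in this assay, and the range must stay wide.

Compound 4 is therefore estimated at 150 nM, expected to fall between 40 nM and 600 nM. This estimate means an expected step of a 1.3-fold higher number from compound 1 to compound 4 (0.10 log units; within the scatter).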

Compound 4, half-maximal inhibitory concentration: 100 nM
The estimate for compound 4 lay 1.5-fold (0.18 log units) above the measured number, and the stated range covers the measured number.
By their numbers in this assay, from the lowest: compounds 4 and 1 (each within the scatter of the next); then compound 3. At a limit, above all of these: compound 2.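

In this assay, for the compounds shown here, the first step at the saturated ring carbon, a 1.2-fold lower number from compound 1 to compound 4 (0.07 log units; within the scatter), lies within the scatter, whereas all the earlier steps, which changed the group on the amide-type nitrogen, lay beyond it. With 3-acetoxyphenyl held on that nitrogen, 4-(dimethylamino)phenyl can therefore stand in place of 2-hydroxyphenyl without a measurable shift in this assay, even though the count of hydrogen-bond donors in the group goes from 1 to 0 and the group grows from 7 to 9 heavy atoms; this rests on a single pair and sets no rule for the position. Nothing measured in the data shown bears on why the number stays put across this change.

Going by these compounds, it remains open whether the same holds when the group on the amide-type nitrogen is pyridin-3-yl or ethyl, since the change at the saturated ring carbon is read here only with 3-acetoxyphenyl. Also open, on these data alone, is how far this position goes with a different kind of group, such as a 4-carboxyphenyl ring or a plain butyl chain in place of the aryl ring.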